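The compounds below may be only part of what the source reports. "The series", "measured", "known", "first", "only" and "open" are said of these compounds alone.

In an ADME assay on MRC5 cells (Homo sapiens) for cytotoxicity, read by fluorescence, with a stated time of 72 h (on this read-out lower numbers stand for stronger inhibition and higher numbers for weaker inhibition), three compounds have been read so far. Compound 1 `CC1(COc2ccc(C(F)(F)F)cn2)Cn2cc([N+](=O)[O-])nc2O1` gives only a limit of the assay, > 64000 nM. Compound 3 `CC1(COc2ccc(-c3ccc(F)cc3)cn2)Cn2cc([N+](=O)[O-])nc2O1` also gives only a limit, > 64000 nM. Compound 3 therefore stands at the limit of > 64000 nM in this assay, at which 2 of the 3 values shown sit, and no true number is known for it. Compound 2 `O=[N+]([O-])c1cn2c(n1)OC(COc1ccc(-c3ccc(C(F)(F)F)cc3)cn1)C2` gives an actual number, 45000 nM.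

The next compound is compound 4 `CC1(COc2ccc(-c3ccc(C(F)(F)F)cc3)cn2)Cn2cc([N+](=O)[O-])nc2O1`. It has trifluoromethyl in place of fluoro on an aromatic carbon, para to a large group, so that 4-fluorophenyl becomes 4-(trifluoromethyl)phenyl: trifluoromethyl in place of fluoro on an aromatic carbon.

Among the measured compounds shown here, the one measured step that bears on this change is a step that the two limits leave unreadable from compound 1 to compound 3, where 4-fluorophenyl comes in place of trifluoromethyl on an aromatic carbon. It offers no size to carry over. The nearest guide is compound 2, since it bears the same 4-(trifluoromethyl)phenyl group and gives 45000 nM. In this assay, a small step is therefore expected, possibly none beyond the scatter, and any movement should lean towards stronger inhibition. The expected change is an at least 1.0-fold lower number from compound 3 to compound 4 (0.02 log units; that floor lies within the scatter). For compound 4 the estimated value is 60000 nM, with an expected range from 30000 nM to 120000 nM.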

Compound 4, half-maximal inhibitory concentration: > 64000 nM
Compound 4: a limit, no number; the forecaster's own chance of this, stated with the estimate: 50%; at least 1.0-fold (0.02 log units) between middle value and limit.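

In this assay, the larger group at this position still gives no number, and compound 4 joins the compounds that stop at a limit: the limit of > 64000 nM in this assay, at which 3 of the 4 values shown sit. The steps to compound 4 from compound 3 and from compound 1 have limits at both ends, so neither can be read, and the swap of fluoro for trifluoromethyl has no measurable size here. Among the compounds shown here, the one readable step, with methyl in place of hydrogen on a saturated ring carbon, is an at least 1.4-fold higher number from compound 2 to compound 4 (0.15 log units; that floor lies within the scatter), which is the first view of this methyl with the 4-(trifluoromethyl)phenyl group held constant, though it does not establish a change beyond the scatter.

Going by these compounds, how far compound 4 lies past its limit stays open, so the true effect of the methyl could be negligible or much larger. On these data alone, it is also open whether an amine or a carboxylic acid in place of trifluoromethyl, on that same six-membered aromatic ring, would give an actual number in this assay rather than another limit.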